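A few compounds are considered here, and "the series" means these few. Any claim that something is new, unique, unknown or untested is made for them only; others in the source may bear on it.

Working notes on the series, read in a functional assay on PC-3 cells (Homo sapiens) for antiproliferative activity, read by sulforhodamine B assay, with a stated time of 48 h; on this read-out higher numbers stand for weaker inhibition and lower numbers for stronger inhibition.

Compound 1 `CC1(C)[C@@H]2CC3=N[C@@H](CCC(=O)O)C(=O)O[C@@]3(C)[C@H]1C2` carries a carboxymethyl group on the saturated chain and in this assay compound 1 gives 42000 nM. Compound 2 `C[C@@H]1N=C2C[C@@H]3C[C@@H](C3(C)C)[C@]2(C)OC1=O` has hydrogen in place of that carboxymethyl, and in this assay compound 2 gives 149000 nM. Within the data shown here, the one counted step between measured compounds, a 3.5-fold higher number from compound 1 to compound 2 (0.55 log units; beyond the scatter), thus goes toward the weaker side.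

Compound 3 `CC1(C)[C@H]2CC3=NCC(=O)O[C@]3(C)[C@@H]1C2` is the smaller core with the same drawn configuration as compound 1 and compound 2. In this assay compound 3 gives only a limit, > 300000 nM, and no number. That puts compound 3 at the limit of > 300000 nM in this assay, at which 1 of the 3 values shown sits, weaker than both numbers reported for compound 1 and compound 2.

Compound 4 `CC1(C)[C@@H]2CC3=NCC(=O)O[C@@]3(C)[C@H]1C2` differs from compound 3 only in configuration: the two compounds have the same atoms and bonds and differ only in configuration as drawn: 3 of 3 stereo elements differ (all stereocentres are inverted: mirror images); a stereocentre at a saturated ring carbon is drawn R in compound 3 and S in compound 4; a stereocentre at a saturated ring carbon is drawn R in compound 3 and S in compound 4; a stereocentre at a saturated ring carbon is drawn R in compound 3 and S in compound 4. Among the measured compounds shown here, no measured step compares mirror images, so the step from compound 1 to compound 2 does not bear directly on this change; the only anchor is the limit of compound 3. The step is therefore expected to be a number no higher from compound 3 to compound 4 (the limit leaves the size open), with no direction that the data support beyond the scatter.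

Estimate for compound 4 in this assay: 300000 nM, with a range from 100000 nM to 1000000 nM, and a high chance that only a limit is reported.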

Compound 4, half-maximal inhibitory concentration: 43000 nM
Beside the measured number, compound 4's estimate is 7.0-fold (0.84 log units) above it; the measured number lies below the stated range.
By their numbers in this assay, from the lowest: compounds 1 and 4 (each within the scatter of the next); then compound 2. At a limit, above all of these: compound 3.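

Inverting all three stereocentres is enough to shift the read-out in this assay, an at least 6.9-fold lower number from compound 3 to compound 4 (0.84 log units; beyond the scatter), and this shift can be put down to configuration alone because no atom or bond changes: the fact that compounds 3 and 4 differ only in the configuration as drawn

With the configuration of compound 4, the substituent on a saturated ring carbon also matters, since hydrogen in place of methyl gives a 3.5-fold lower number from compound 2 to compound 4 (0.54 log units; beyond the scatter). Hydrogen in place of 2-carboxyethyl on a saturated ring carbon, by contrast, gives a 1.0-fold higher number from compound 1 to compound 4 (0.01 log units; within the scatter), so the two compounds cannot be told apart in this assay and the longer acid-bearing chain shows no gain over hydrogen.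

As far as these compounds go, compound 3 gives only a limit, > 300000 nM, so the full size of the step between the mirror images stays open. Also open, from the compounds shown here alone, is whether an amine or a simple ethyl group on that saturated ring carbon would move the number beyond the scatter relative to compound 4.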